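Swapping Methoxy for Bromo at a Shared Limit

The source may hold more compounds than are shown below. What is called first, only, known or untested is meant among the compounds shown, and "the series" means these compounds.

Three close analogues share one core. Compound 1 is `N#Cc1c(-c2cccc(Cl)c2)c(C#N)c(=O)n(/N=C/c2cn(-c3ccccc3)nc2-c2ccccc2)c1N`, compound 2 is `N#Cc1c(-c2cccc(F)c2)c(C#N)c(=O)n(/N=C/c2cn(-c3ccccc3)nc2-c2ccccc2)c1N` and compound 3 is `COc1ccc(-c2c(C#N)c(N)n(/N=C/c3cn(-c4ccccc4)nc3-c3ccccc3)c(=O)c2C#N)cc1`. In an ADME assay on HeLa cells (Homo sapiens) for cytotoxicity, read by MTT assay (a higher number here means a weaker inhibitor, a lower number a stronger inhibitor), compound 1 gives > 200 ug/mL, which is a limit of the assay rather than a number. Compound 2 gives > 200 ug/mL, again only a limit. Compound 3 gives > 200 ug/mL, also a limit. Because all three values sit at the limit of > 200 ug/mL in this assay, at which 3 of the 3 values shown sit, none of the steps between them can be sized: a step that the two limits leave unreadable from compound 1 to compound 2, a step that the two limits leave unreadable from compound 1 to compound 3 and a step that the two limits leave unreadable from compound 2 to compound 3 are all unreadable. Compound 3 therefore stands where every measured compound stands, at the limit, with nothing shown to set it apart.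

The unmeasured compound 4 is `N#Cc1c(-c2ccc(Br)cc2)c(C#N)c(=O)n(/N=C/c2cn(-c3ccccc3)nc2-c2ccccc2)c1N`. It differs from compound 3 by bromo in place of methoxy on an aromatic carbon. The three measured steps bear on this change only by showing that the exchanges of chloro, fluoro and methoxyphenyl groups have not moved any compound off the limit. The step from compound 3 to compound 4 is expected to be a step that the limit leaves unreadable from compound 3 to compound 4, with no shift beyond the scatter in this assay anticipated. Compound 4 is estimated at 250 ug/mL, within 100 ug/mL to 600 ug/mL, most probably reported again as a limit.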

Compound 4, half-maximal inhibitory concentration: > 200 ug/mL
Compound 4: a limit, no number; the forecaster's own chance of this, stated with the estimate: 85%; the middle value does not contradict the limit.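

No step from compound 1, compound 2 or compound 3 to compound 4 can be read, because each result in this assay is a limit and not a number: the limit of > 200 ug/mL in this assay, at which 4 of the 4 values shown sit.

The compounds shown leave open how far apart these four really lie in this assay, and whether exchanging these groups changes the result at all.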